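A few compounds are considered here, and "the series" means these few. Any claim that something is new, unique, unknown or untested is made for them only; others in the source may bear on it.

Compound 1 `O[C@H](COCCOC[C@@H](O)Cc1cn(-c2ccc3c(c2)OCCO3)nn1)Cc1ccc(-c2ccccc2)cc1` carries a 2,3-dihydro-1,4-benzodioxin-6-yl group on an aromatic nitrogen, and in a functional assay on SGC-7901 cells (Homo sapiens) for inhibition, read by MTT assay, with a stated time of 72 h (a higher number here means a weaker inhibitor of growth, a lower number a stronger inhibitor of growth), compound 1 gives 6400 nM. Compound 2 `O[C@H](COCCOC[C@@H](O)Cc1cn(Cc2ccc3ccccc3c2)nn1)Cc1ccc(-c2ccccc2)cc1`, with (naphthalen-2-yl)methyl in that place, gives 12100 nM in this assay, and the difference between the two is a 1.9-fold higher number from compound 1 to compound 2 (0.28 log units; within the scatter). Compound 3 `O[C@H](COCCOC[C@@H](O)Cc1cn(-c2cncnc2)nn1)Cc1ccc(-c2ccccc2)cc1` carries pyrimidin-5-yl there. For compound 3 this assay reports only a limit, > 100000 nM, so its true number is not known. Against the other two this amounts to an at least 15-fold higher number from compound 1 to compound 3 (1.19 log units; beyond the scatter) and an at least 8.2-fold higher number from compound 2 to compound 3 (0.91 log units; beyond the scatter).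

Compound 4 `O[C@H](COCCOC[C@@H](O)Cc1cn(-c2cncc3ccccc23)nn1)Cc1ccc(-c2ccccc2)cc1` has not yet been measured. It differs from compound 3 by isoquinolin-4-yl in place of pyrimidin-5-yl on an aromatic nitrogen. The change restores a two-ring aromatic group of the kind carried by compound 1 and compound 2, both of which gave measurable numbers in this assay, so the step from the pyrimidin-5-yl analogue is expected to bring the number down by a sizeable margin. The expected step is an at least 6.6-fold lower number from compound 3 to compound 4 (0.82 log units; beyond the scatter). Compound 4 is estimated at 15000 nM, with a likely range from 5000 nM to 60000 nM.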

Compound 4, concentration for 50% growth inhibition: 29300 nM
Compound 4: middle estimate off by 2.0-fold (0.29 log units), on the low side; the measured number falls inside the stated range.
By their numbers in this assay, from the lowest: compounds 1 and 2 (each within the scatter of the next); then compound 4. At a limit, above all of these: compound 3.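

Replacing pyrimidin-5-yl with isoquinolin-4-yl on this aromatic nitrogen gives a measurable number, with an at least 3.4-fold lower number from compound 3 to compound 4 (0.53 log units; beyond the scatter); this step is only a bound, since compound 3 is known only through a limit: the limit of > 100000 nM in this assay, at which 1 of the 4 values shown sits. A two-ring group alone does not match the other two compounds, as the same group gives a 4.6-fold higher number from compound 1 to compound 4 (0.66 log units; beyond the scatter) and a 2.4-fold higher number from compound 2 to compound 4 (0.38 log units; beyond the scatter). Among these four compounds, the two groups with a nitrogen in their rings, pyrimidin-5-yl and isoquinolin-4-yl, give the two highest readings, although those groups also differ in other ways.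

Going by these compounds, it remains open what naphthalen-2-yl set directly on the aromatic nitrogen would give, which would compare isoquinolin-4-yl with a carbon-only group of the same ring count. The effect of a simple phenyl ring bearing an amine in this place is also unknown.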